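A few compounds are considered here, and "the series" means these few. Any claim that something is new, unique, unknown or untested is made for them only; others in the source may bear on it.

Compound 3 `COCCCn1cc(C(=O)Nc2ccc(-c3cn(C)c4ncnc(N)c34)cc2)c(=O)c(-c2ccc(F)cc2)c1` stands at the edge of what the numbers can say. In an assay on isolated protein for inhibition of tyrosine-protein kinase receptor UFO (Homo sapiens), read by ELISA (a higher number here means a weaker inhibitor, a lower number a stronger inhibitor), compound 3 gives only > 10 nM, which is a limit of the assay rather than a number. Its nearest measured relative, compound 1 `Cn1cc(-c2ccc(NC(=O)c3cn(CC4CCCCC4)cc(-c4ccc(F)cc4)c3=O)cc2)c2c(N)ncnc21`, differs from it in one place only, and in this assay compound 1 gives 2.3 nM. Going by the values given here, the step of an at least 4.3-fold higher number from compound 1 to compound 3 (0.63 log units; beyond the scatter) is the only measured step that touches compound 3, and its size rests on (the limit of > 10 nM in this assay, at which 1 of the 3 values shown sits). Among the compounds with values here, compound 2 `Cn1cc(-c2ccc(NC(=O)c3cn(CC4CCOCC4)cc(-c4cccc(F)c4)c3=O)cc2)c2c(N)ncnc21` carries an oxygen-containing saturated ring at the same position, and in this assay compound 2 gives 3 nM; no single step links it to compound 3.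

Compound 4 `Cn1cc(-c2ccc(NC(=O)c3cn(CC4CCCO4)cc(-c4ccc(F)cc4)c3=O)cc2)c2c(N)ncnc21` has not yet been measured. It differs from compound 3 by oxolan-2-yl in place of 2-methoxyethyl on a saturated chain carbon bound to an aromatic nitrogen. Within the data shown here, the change closes the open chain of compound 3 into a ring, moving back toward the ring-bearing compounds 1 and 2, so a partial recovery of the loss seen in the only measured step is expected, although no measured step covers a five-membered ring here. The step expected is an at least 1.4-fold lower number from compound 3 to compound 4 (0.15 log units; that floor lies within the scatter). Compound 4 is therefore estimated to give about 7 nM in this assay, within a range from 2.5 nM to 25 nM.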

Compound 4, half-maximal inhibitory concentration: 1.2 nM
Estimate against measurement, compound 4: 5.8-fold (0.77 log units) above, outside the stated range (below it).
By their numbers in this assay, from the lowest: compounds 4, 1 and 2 (each within the scatter of the next, the first and the last beyond it). At a limit, above all of these: compound 3.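

Replacing the 3-methoxypropyl of compound 3 with the (oxolan-2-yl)methyl of compound 4 leaves the count of hydrogen-bond acceptors and donors unchanged, yet in this assay it gives an at least 8.3-fold lower number from compound 3 to compound 4 (0.92 log units; beyond the scatter) and so shows that, at this saturated chain carbon bound to an aromatic nitrogen, that count alone does not set the result. Going by these compounds, for compound 3 the value is a limit of the assay and not a number, so this step gives only a floor and its true size stays unknown: (the limit of > 10 nM in this assay, at which 1 of the 4 values shown sits). The other new comparison, a 1.9-fold lower number from compound 1 to compound 4 (0.28 log units; within the scatter), sets the oxygen-containing five-membered ring level with cyclohexyl within the scatter, so among compounds 1, 3 and 4 only the open chain of compound 3 stands apart.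

The compounds shown do not separate the effect of the ring from that of its oxygen, which leaves open how a cyclopentyl group or an open pentyl chain with no oxygen would read at this position. They also leave open whether a ring carrying an amine, such as piperidin-4-yl, would be tolerated here as well as cyclohexyl and oxolan-2-yl are.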